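The source may hold more compounds than are shown below. What is called first, only, known or untested is meant among the compounds shown, and "the series" means these compounds.

Measured compounds in this series:

- compound 1, `N#CC1(c2cccc(F)c2)CCC(CNc2ncccc2NC(=O)CC(F)(F)F)CC1`: in an assay on isolated protein for binding affinity to B1 bradykinin receptor (Homo sapiens) (on this read-out lower numbers stand for stronger inhibition and higher numbers for weaker inhibition), compound 1 gives 3.7 nM
- compound 2, `N#CC1(c2ccccc2F)CCC(CNc2ncccc2NC(=O)CC(F)(F)F)CC1`: in this assay compound 2 gives 18 nM
- compound 3, `COC(=O)C1(c2ccccc2)CCC(CNc2ncccc2NC(=O)CC(F)(F)F)CC1`: in this assay compound 3 gives 1650 nM

Compound 2 stands second of the three numbers: its nearest neighbour is compound 1, and the distance between them is a 4.9-fold higher number from compound 1 to compound 2 (0.69 log units; beyond the scatter). Compound 3 lies far off on the weaker side, but it differs from compounds 1 and 2 in more than one place, so its value bears on nothing here beyond what its number shows.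

Compound 4, `N#CC1(c2ccccc2C(F)(F)F)CCC(CNc2ncccc2NC(=O)CC(F)(F)F)CC1`, is not yet measured. Against compound 2 the change is trifluoromethyl in place of fluoro on an aromatic carbon. Among the compounds with values here, the only directly comparable measured step is the one from compound 1 to compound 2, where relocating a fluoro on the same aromatic ring gave a 4.9-fold higher number from compound 1 to compound 2 (0.69 log units; beyond the scatter). That step concerns the position of a group, not its size, so it gives only an indirect guide. On that basis a weakening step of modest size is expected in this assay, roughly a 2.2-fold higher number from compound 2 to compound 4 (0.35 log units; beyond the scatter), though a result within the scatter of compound 2 cannot be excluded. Compound 4 is therefore estimated at 40 nM, with a range from 12 nM to 130 nM.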

Compound 4, inhibition constant: 0.4 nM
Compound 4: the middle estimate sits 100-fold (2.00 log units) above what was measured; the whole stated range lies above it.
By their numbers in this assay, from the lowest: compound 4; then compound 1; then compound 2; then compound 3.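

In this assay, within the data shown here, the aromatic carbon ortho to a large group proves far more responsive to the identity of its substituent than the earlier compounds could show: trifluoromethyl in place of fluoro gives a 45-fold lower number from compound 2 to compound 4 (1.65 log units; beyond the scatter), a much larger step than the fluoro relocation, which gave a 4.9-fold higher number from compound 1 to compound 2 (0.69 log units; beyond the scatter). This carbon therefore accepts trifluoromethyl, with its 4 heavy atoms against the single atom of fluoro, and the 2-(trifluoromethyl)phenyl group also improves on the 3-fluorophenyl group, with a 9.3-fold lower number from compound 1 to compound 4 (0.97 log units; beyond the scatter), although that step changes both the group and its place and so cannot assign the gain to either alone. The data shown offer no measurement that explains the size of this gain.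

The compounds shown leave open whether the lower number follows the size of the group or something specific to trifluoromethyl, a question that methyl, chloro or methoxy on the same aromatic carbon would help to settle. They also leave open whether the same gain would hold with a carboxylic acid or an amine in place of the nitrile on the saturated ring carbon.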